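Dimethoxyphenyl swap on the pyrimidinone arm of the series

The source may report more compounds than this note shows. Statements on the series, on what has been measured and on what is new or still open speak of the compounds shown alone.

Measured compounds:
Compound 1, `COc1ccc(-c2nc(C)c(C(=O)CSc3nc(-c4ccc(OC)c(OC)c4)c(C#N)c(=O)[nH]3)s2)cc1` — 22.2%
Compound 2, `Cc1nc(-c2ccccc2)sc1C(=O)CSc1nc(-c2ccccc2)c(C#N)c(=O)[nH]1` — 77.5%

Two members of the series have been read in a functional assay on U-87MG ATCC cells for antiproliferative activity against U-87 MG (Homo sapiens), read by MTT assay, with a stated time of 48 h, tested at 50 uM; on this read-out higher numbers stand for a weaker effect at the one concentration tested and lower numbers for a stronger effect. Compound 1 gives 22.2% in this assay. Compound 2 gives 77.5% in this assay, the highest of the two numbers; its nearest neighbour is compound 1, whose number lies lower by a gap beyond the scatter. Since the two differ in more than one place, the gap is reported as it stands and not assigned to any single change.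

Compound 3, `COc1ccc(-c2nc(SCC(=O)c3sc(-c4ccccc4)nc3C)[nH]c(=O)c2C#N)cc1OC`, is not yet measured. Relative to compound 2 the change is 3,4-dimethoxyphenyl in place of phenyl on an aromatic carbon. Going by the values given here, no single-point step between measured compounds exists for this change, so the expectation rests on the two values only. Because compound 1, which carries 3,4-dimethoxyphenyl groups, gives 22.2%, the step from compound 2 to compound 3 is expected to move the number downward, by roughly a number 32.5 percentage points lower from compound 2 to compound 3 (beyond the scatter), a step larger than the scatter. Compound 3 is accordingly estimated at 45%, with a range from 25% to 70%.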

Compound 3, a percentage reported as activity, at one concentration (the size of the read-out at that concentration, not a potency): 21.4%
Compound 3: the middle estimate sits 23.6 percentage points above what was measured; the measured number lies below the stated range.
By their numbers in this assay, from the lowest: compounds 3 and 1 (each within the scatter of the next); then compound 2.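

In this assay, 3,4-dimethoxyphenyl in place of phenyl on the aromatic carbon next to the ring nitrogen and ortho to a cyano group gives a number 56.1 percentage points lower from compound 2 to compound 3 (beyond the scatter) and so shows, as a single change, that this position is sensitive to what it carries, which the two earlier compounds, differing in more than one place, could not show. Hydrogen in place of methoxy on an aromatic carbon gives a number 0.8 percentage points lower from compound 1 to compound 3 (within the scatter) and so, for this pair, the extra methoxy of compound 1 produces no readable change, leaving the 3,4-dimethoxyphenyl swap as the one step of the two that registers beyond the scatter. Nothing on hand gives a measured property that would account for the large step.

Still open, as far as these compounds go, is whether one methoxy of the 3,4-dimethoxyphenyl group would carry the step alone, or whether both are needed, as a 4-methoxyphenyl or 3-methoxyphenyl group at this carbon would tell. Also open, from the compounds shown here alone, is how a different kind of group here, such as an amine, a carboxylic acid or a longer alkyl chain, would read, and the single concentration gives no potency for any of the three compounds.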